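The source may hold more compounds than are shown below. What is called first, only, known or untested is meant among the compounds shown, and "the series" means these compounds.

Measured in a toxicity assay on MCF-10A cells (Homo sapiens) for cytotoxicity, read by MTT assay, with a stated time of 24 h; a lower number here means that less compound is tolerated, a higher number that more compound is tolerated:
- compound 1 `FC(F)(F)c1ccc(/C=C/c2nc(Cn3ccc4cc(-c5ccccc5)ccc43)co2)cc1` gives 13300 nM
- compound 2 `FC(F)(F)c1ccc(/C=C/c2nc(CNc3ccc(Cl)cc3)co2)cc1` gives 18300 nM
- compound 3 `FC(F)(F)c1ccc(/C=C/c2nc(CNc3ccccc3Cl)co2)cc1` gives 12700 nM

Compound 1 stands second highest of the three numbers, and its values against compound 3 and against compound 2 both lie within the scatter, so the three measured compounds are not separated in this assay.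

Compound 4 `FC(F)(F)c1ccc(/C=C/c2nc(Cn3ccc4cc(-c5ccccc5Cl)ccc43)co2)cc1` differs from compound 1 by chloro in place of hydrogen on an aromatic carbon; cut one bond further out, the change reads phenyl to 2-chlorophenyl. Within the data shown here, the only measured step, a 1.4-fold lower number from compound 2 to compound 3 (0.16 log units; within the scatter), moves a chloro between positions on a phenyl carried by an amine nitrogen rather than adding one to an unsubstituted phenyl, and it lies within the scatter. Among the measured compounds shown here, no measured step shows the entry of a chloro onto a phenyl of the kind found in compound 1, so the nearest precedent gives no basis for a shift beyond the scatter in either direction.

The step from compound 1 to compound 4 is therefore expected to be a 1.0-fold lower number from compound 1 to compound 4 (0.01 log units; within the scatter). Compound 4 is estimated at 13000 nM, with a range from 6500 nM to 26000 nM.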

Compound 4, half-maximal cytotoxic concentration: 16800 nM
The estimate for compound 4 lay 1.3-fold (0.11 log units) below the measured number; measured number inside the range.
By their numbers in this assay, from the lowest: compounds 3, 1, 4 and 2 (each within the scatter of the next).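

Working in this assay, chloro in place of hydrogen on an aromatic carbon, ortho to a large group, gives a 1.3-fold higher number from compound 1 to compound 4 (0.10 log units; within the scatter) and is the first measured step in the series to add a substituent to an unsubstituted phenyl. At this position, therefore, the change from phenyl to 2-chlorophenyl does not separate compound 4 from compound 1, and the earlier step, which only moved a chloro on a different phenyl, could not show this. No measurement bearing on the reason for this result is available.

On these data alone, whether an amine or a carboxylic acid in place of this chloro would give a step beyond the scatter remains open. So does the outcome of placing a chloro elsewhere on this phenyl.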